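Swapping the sulfanyl group of compound 3 for an aryl sulfonyl

The source may hold more compounds than are shown below. What is called first, only, known or untested is meant among the compounds shown, and "the series" means these compounds.

In a functional assay on DU-145 cells (Homo sapiens) for inhibition, read by trypan blue exclusion, with a stated time of 96 h (a higher number here means a weaker inhibitor of growth, a lower number a stronger inhibitor of growth), compound 1 (`Cc1ccc(CS(=O)(=O)/C(=C/c2ccccc2OCc2ccccc2)C(=O)c2ccc(Cl)cc2)cc1`) gives 1000 nM as the lowest of three numbers. Compound 2 (`O=C(/C(=C\c1ccccc1OCc1ccccc1)S(=O)(=O)Cc1ccc(F)cc1)c1ccc(Cl)cc1`) gives 10000 nM and compound 3 (`O=C(/C(=C\c1ccccc1OCc1ccccc1)SCc1ccc(Cl)c(Cl)c1)c1ccc(Cl)cc1`) gives 10000 nM at the digits shown, so these two sit level at the top. Compound 4 (`COc1ccc(S(=O)(=O)/C(=C/c2ccccc2OCc2ccccc2)C(=O)c2ccc(Cl)cc2)cc1`) has (4-methoxyphenyl)sulfonyl in place of (3,4-dichlorobenzyl)sulfanyl on a double-bonded chain carbon bound to a carbonyl carbon and a double-bonded chain carbon. Two measured steps have (3,4-dichlorobenzyl)sulfanyl entering at that place: one shows a 10-fold higher number from compound 1 to compound 3 (1.00 log units; beyond the scatter) and the other shows no change at the digits printed from compound 2 to compound 3 (within the scatter) for the same kind of exchange. Among the sulfonyl compounds the data also show a 10-fold higher number from compound 1 to compound 2 (1.00 log units; beyond the scatter) on a single aromatic substituent. Within the data shown here, no measured compound carries (4-methoxyphenyl)sulfonyl, so the reading is loose. A modest move to a lower number is expected, amounting to a 3.3-fold lower number from compound 3 to compound 4 (0.52 log units; beyond the scatter) in this assay as the estimated step. Compound 4 is estimated at 3000 nM with an expected range from 700 nM to 12000 nM in this estimate.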

Compound 4, concentration for 50% growth inhibition: 1000 nM
Compound 4: the middle estimate sits 3.0-fold (0.48 log units) above what was measured; low and high end bracket the measured number.
By their numbers in this assay, from the lowest: compounds 1 and 4 (each within the scatter of the next); then compounds 2 and 3 (each within the scatter of the next).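

In this assay, (4-methoxyphenyl)sulfonyl in place of (3,4-dichlorobenzyl)sulfanyl on the double-bonded chain carbon gives a 10-fold lower number from compound 3 to compound 4 (1.00 log units; beyond the scatter) and shows that this position can return to a lower number with an aryl group directly on the sulfonyl sulfur. On that sulfur, 4-methoxyphenyl in place of 4-fluorobenzyl gives a 10-fold lower number from compound 2 to compound 4 (1.00 log units; beyond the scatter) while 4-methoxyphenyl in place of 4-methylbenzyl gives no change at the digits printed from compound 1 to compound 4 (within the scatter) and so the same incoming group reads differently depending on the benzyl group it replaces, with compound 1 and compound 4 level. No supporting data are available to explain these steps.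

The exchange from compound 3 to compound 4 alters the sulfur and its substituent together, so the contribution of each remains unresolved. On these data alone, how an amine or a carboxylic acid in place of the methoxy group would read also remains open.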